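Ester to azetidine amide on a naphthyl pyridine acrylate

The compounds below may be only part of what the source reports. "The series", "measured", "known", "first", "only" and "open" are said of these compounds alone.

Compound 1 `O=C(O)[C@@H]1CCCN1C(=O)/C=C/c1ccncc1-c1ccc2ccccc2c1`, in an assay on a protein complex for inhibition of CDK8/Cyclin C (Homo sapiens), with a stated time of 1 h, tested at 10 uM (on this read-out lower numbers stand for less inhibition and higher numbers for more inhibition at the one concentration tested (going by the name of the read-out)), compound 1 gives 67%.
Compound 2 `CCOC(=O)/C=C/c1ccncc1-c1ccc2ccccc2c1`, in this assay compound 2 gives 102%.

Compound 2 stands highest of the two numbers; the nearest is compound 1, which lies a number 35 percentage points higher from compound 1 to compound 2 (beyond the scatter). Compound 3 `COC1CN(C(=O)/C=C/c2ccncc2-c2ccc3ccccc3c2)C1` differs from compound 2 by 3-methoxyazetidin-1-yl in place of ethoxy on a carbonyl carbon. Among the compounds with values here, the only step that bears on this is the one from compound 1 to compound 2, where a carbonyl amide gave way to an ester and the number rose by that large margin. Going back from ester to an amide, here without the acid, a downward step is expected, probably smaller: a number 17 percentage points lower from compound 2 to compound 3 (beyond the scatter). Compound 3 is estimated at 85%, within 55% to 102%.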

Compound 3, a percentage reported as inhibition, at one concentration (the size of the read-out at that concentration, not a potency): 100%
For compound 3 the middle estimate is 15 percentage points below the measured one, within the range that was stated.
By their numbers in this assay, from the lowest: compound 1; then compounds 3 and 2 (each within the scatter of the next).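

In this assay an amide on this carbonyl carbon reads the same as the ester: the step gives a number 2 percentage points lower from compound 2 to compound 3 (within the scatter) and so the two numbers cannot be told apart. An amide at this place therefore does not by itself go with a lower number, since the other step gives a number 33 percentage points higher from compound 1 to compound 3 (beyond the scatter) on the same core. Nothing measured here gives a reason for either step.

From the compounds shown here alone, it stays open whether the lower number of compound 1 goes with its carboxylic acid or with its pyrrolidine ring, which a plain pyrrolidine amide would separate. An unsubstituted azetidine amide would show whether the methoxy group matters.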